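Ester variation on the urea arm of the series

A few compounds are considered here, and "the series" means these few. Any claim that something is new, unique, unknown or untested is made for them only; others in the source may bear on it.

Compound 1 `Cc1cc(C(=O)N2CCCCc3ccccc32)ccc1CNC(=O)NCC(=O)OC(C)C` gives in a functional assay on HEK293 cells for agonist activity at Vasopressin V2 receptor (Homo sapiens), read by a luciferase reporter and cAMP accumulation (on this read-out lower numbers stand for an effect already at smaller amounts and higher numbers for an effect only at larger amounts of compound), a value of 140 nM. Compound 2 `COC(=O)[C@@H]1CCCN1C(=O)NCc1ccc(C(=O)N2CCCCc3ccccc32)cc1C` gives in this assay a value of 100 nM. Compound 2 has the lowest of the two numbers, but the step of a 1.4-fold lower number from compound 1 to compound 2 (0.15 log units; within the scatter) lies within the scatter, so no order between the two is claimed.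

Compound 3 `Cc1cc(C(=O)N2CCCCc3ccccc32)ccc1CNC(=O)N1CCC[C@H]1C(=O)OC(C)(C)C` differs from compound 2 by tert-butyl in place of methyl on an oxygen next to a carbonyl group. Going by the values given here, the only step at hand, a 1.4-fold lower number from compound 1 to compound 2 (0.15 log units; within the scatter), reshaped the ester-bearing arm without moving the number beyond the scatter, and nothing measured separates ester sizes from one another. The ester change from compound 2 to compound 3 is therefore expected to give no step beyond the scatter, with the estimated step of a 1.1-fold higher number from compound 2 to compound 3 (0.04 log units; within the scatter). Compound 3 is estimated at 110 nM in this assay, with a range from 40 nM to 320 nM.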

Compound 3, half-maximal effective concentration: 390 nM
Estimate against measurement, compound 3: 3.5-fold (0.55 log units) below; measured number outside the range, above it.
By their numbers in this assay, from the lowest: compounds 2 and 1 (each within the scatter of the next); then compound 3.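

In this assay, going by these compounds alone, the group on the ester oxygen does count: tert-butyl in place of methyl gives a 3.9-fold higher number from compound 2 to compound 3 (0.59 log units; beyond the scatter) and is the first single change to go beyond the scatter. The 2-(tert-butoxycarbonyl)pyrrolidin-1-yl arm also stands apart from the ((isopropoxycarbonyl)methyl)amino arm, with a 2.8-fold higher number from compound 1 to compound 3 (0.44 log units; beyond the scatter) as the step, so the pyrrolidine-bearing arm does not by itself keep the number low and the ester on it has a say. Nothing at hand bears on the reason for this rise.

The compounds shown leave open whether the number climbs stepwise from methyl to tert-butyl, which ethyl or isopropyl on the same arm would test. Also open, going by these compounds, is whether this arm needs an ester at all, a question for a carboxylic acid or a primary amide in its place.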